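Adding a Methoxy Group: From Compound 1 to Compound 3

The source may hold more compounds than are shown below. What is called first, only, known or untested is meant among the compounds shown, and "the series" means these compounds.

Compound 1, `COc1ccc(-c2[nH]c3ccccc3c2/C=C(\C#N)S(=O)(=O)c2ccccc2)cc1`: 4700 nM
Compound 2, `COc1ccc2[nH]c(-c3ccccc3)c(C=C(C#N)C#N)c2c1`: 6400 nM

In a functional assay on UO-31 cells (Homo sapiens) for inhibition, read by sulforhodamine B assay, with a stated time of 48 h (a higher number here means a weaker inhibitor of growth, a lower number a stronger inhibitor of growth), compound 1 gives 4700 nM, the lower of the two numbers, though compound 2 with 6400 nM lies within the scatter of it, so no order between them can be claimed. Compound 3, `COc1ccc(-c2[nH]c3ccc(OC)cc3c2/C=C(\C#N)S(=O)(=O)c2ccccc2)cc1`, is not yet measured. It differs from compound 1 by methoxy in place of hydrogen on an aromatic carbon. Within the data shown here, no measured pair shows the effect of such a change, so a step no larger than the scatter, in either direction, is expected: a 1.0-fold lower number from compound 1 to compound 3 (0.02 log units; within the scatter). Compound 3 is therefore expected to give 4500 nM, in the range 1500 nM to 13000 nM.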

Compound 3, concentration for 50% growth inhibition: 3100 nM
Beside the measured number, compound 3's estimate is 1.5-fold (0.16 log units) above it, and the stated range covers the measured number.
By their numbers in this assay, from the lowest: compounds 3, 1 and 2 (each within the scatter of the next, the first and the last beyond it).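

Among these compounds, this is the first measured pair for this change: putting methoxy in place of hydrogen on this aromatic carbon gives a 1.5-fold lower number from compound 1 to compound 3 (0.18 log units; within the scatter) in this assay. The position therefore accepts methoxy, with no difference that can be told apart from the scatter of repeated measurements. No measurement shown here bears on what lies behind this result.

Going by these compounds, whether an amine, a hydroxy group or a longer chain such as ethoxy on this carbon would move the number beyond the scatter remains open. So does the effect of methoxy on the other carbons of this ring.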